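Swapping one five-membered azole for another

This account rests on a few compounds, and the source may have more. Where it says the series, first, only, none or still open, it means among the compounds named here.

The measured compounds, each with its result in a functional assay on KU812 cells (Homo sapiens) for antiproliferative activity; a higher number here means a weaker inhibitor, a lower number a stronger inhibitor:
Compound 1, `Cc1cn(-c2cc(NC(=O)c3ccc(C)c(Nc4nc(-c5cccnc5)cs4)c3)cc(C(F)(F)F)c2)cn1`, compound 1 gives 30 nM.
Compound 2, `Cc1ccc(C(=O)Nc2cc(-n3ccnc3)cc(C(F)(F)F)c2)cc1Nc1nc(-c2cccnc2)cs1`, compound 2 gives 36 nM.
Compound 3, `Cc1ncn(-c2cc(NC(=O)c3ccc(C)c(Nc4nc(-c5cccnc5)cs4)c3)cc(C(F)(F)F)c2)n1`, compound 3 gives 38 nM.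

All three share one core and differ only in the azole attached to the ring that also carries the trifluoromethyl group. Compound 3 sits within the scatter of both others: a 1.3-fold higher number from compound 1 to compound 3 (0.10 log units; within the scatter) and a 1.1-fold higher number from compound 2 to compound 3 (0.02 log units; within the scatter), so no real separation among them can be claimed.

Compound 4, `Cc1ccc(C(=O)Nc2cc(-c3cnn(C)c3)cc(C(F)(F)F)c2)cc1Nc1nc(-c2cccnc2)cs1`, has not been measured. It arises from compound 3 through (1-methyl-1H-pyrazol-4-yl in place of 3-methyl-1H-1,2,4-triazol-1-yl on an aromatic carbon). The two steps that bear on it, from compound 1 to compound 3 and from compound 2 to compound 3, each exchange one azole for another at the same carbon, and neither moved the number beyond the scatter. Because a 1.1-fold higher number from compound 2 to compound 3 (0.02 log units; within the scatter) and a 1.3-fold higher number from compound 1 to compound 3 (0.10 log units; within the scatter) were both small, compound 4 is expected to stay close to compound 3, with a step of a 1.1-fold lower number from compound 3 to compound 4 (0.04 log units; within the scatter) in this assay and no direction beyond the scatter. Compound 4 is therefore estimated at 35 nM, in the range 15 nM to 85 nM.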

Compound 4, half-maximal inhibitory concentration: 27.1 nM
The estimate for compound 4 lay 1.3-fold (0.11 log units) above the measured number, within the range that was stated.
By their numbers in this assay, from the lowest: compounds 4, 1, 2 and 3 (each within the scatter of the next).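

In this assay, compound 4 brings a new kind of attachment: 1-methyl-1H-pyrazol-4-yl is joined through the ring atom numbered 4 in its name, whereas the earlier azoles are joined through the atom numbered 1. All three new steps stay within the scatter (a 1.4-fold lower number from compound 3 to compound 4 (0.15 log units; within the scatter); a 1.3-fold lower number from compound 2 to compound 4 (0.12 log units; within the scatter); a 1.1-fold lower number from compound 1 to compound 4 (0.04 log units; within the scatter)). This carbon, meta to a trifluoromethyl group, therefore tolerates a change in how the azole is joined as well as a change in which azole it carries, and nothing available explains why the numbers stay so close.

Every group shown here is a five-membered azole, so the effect of a quite different group at this carbon, such as an amine, a carboxylic acid or a longer alkyl chain, remains open. As far as these compounds go, whether these azoles would also stay together in any other test remains open too.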